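The source may hold more compounds than are shown below. What is called first, only, known or untested is meant among the compounds shown, and "the series" means these compounds.

Compound 1 `CCC(=O)NC[C@@H]1CC1c1cccc2oc(CCCCc3ccccc3)cc12` gives 2.8 nM in an assay on NIH3T3 cells for binding affinity to melatonin receptor type 1B (Homo sapiens) (on this read-out lower numbers stand for stronger inhibition and higher numbers for weaker inhibition), the lowest of the three numbers measured. Compound 3 `CC(C)C(=O)NCCCc1cccc2oc(CCCCc3ccccc3)cc12` gives 83 nM and compound 2 `CCNC(=O)NC[C@@H]1C[C@H]1c1cccc2oc(CCCCc3ccccc3)cc12` gives 90 nM. Compound 4 `CCNC(=O)NCCCc1cccc2oc(CCCCc3ccccc3)cc12` carries 3-((ethylcarbamoyl)amino)propyl in place of 2-((propanoylamino)methyl)cyclopropyl on an aromatic carbon. This joins two changes: the chain already seen in compound 3, where a 30-fold higher number from compound 1 to compound 3 (1.47 log units; beyond the scatter), and the ethylurea end seen in compound 2, whose number is far above that of compound 1. Since each change alone weakened binding, a large rise in this assay is expected for compound 4, though the two effects need not add fully. Compound 4 is therefore estimated at 500 nM, with a range from 80 nM to 3000 nM, a step of a 180-fold higher number from compound 1 to compound 4 (2.25 log units; beyond the scatter).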

Compound 4, inhibition constant: 52 nM
Estimate against measurement, compound 4: 9.6-fold (0.98 log units) above; measured number outside the range, below it.
By their numbers in this assay, from the lowest: compound 1; then compounds 4, 3 and 2 (each within the scatter of the next).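

In this assay the open 3-((ethylcarbamoyl)amino)propyl chain on this aromatic carbon binds far less well than the 2-((propanoylamino)methyl)cyclopropyl group of the parent (a 19-fold higher number from compound 1 to compound 4 (1.27 log units; beyond the scatter)). On the open propyl chain, ethylamino in place of isopropyl on the carbonyl carbon leaves the number within the scatter (a 1.6-fold lower number from compound 3 to compound 4 (0.20 log units; within the scatter)), so the end group makes no clear difference there. Nothing available here explains either result.

Going by these compounds, how much of the large step belongs to losing the cyclopropyl ring alone stays open. So does how a cyclobutyl ring or a longer chain would behave at this position.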